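This account rests on a few compounds, and the source may have more. Where it says the series, first, only, none or still open, it means among the compounds named here.

Measured in a functional assay on A549 cells (Homo sapiens) for antiproliferative activity, read by XTT assay, with a stated time of 72 h; on this read-out higher numbers stand for weaker inhibition and lower numbers for stronger inhibition:
compound 1 `COc1ccc(-c2cc3ccccc3nc2/C=C/C(=O)c2ccc(OC)c(OC)c2)cc1`, 8860 nM
compound 2 `COc1ccc(-c2cc3ccccc3nc2/C=C/C(=O)c2cccs2)cc1`, 920 nM
compound 3 `COc1ccc(-c2cc3ccccc3nc2/C=C/C(=O)c2ccccn2)cc1`, 6140 nM

Compound 3 holds the second highest of the three numbers. Going by the values given here, its nearest neighbour lies within the scatter a 1.4-fold lower number from compound 1 to compound 3 (0.16 log units; within the scatter); the only step beyond the scatter separates it from the lowest number of the set a 6.7-fold higher number from compound 2 to compound 3 (0.82 log units; beyond the scatter).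

Compound 4 `COc1ccc(-c2cc3ccccc3nc2/C=C/C(=O)c2ccc(Br)s2)cc1` differs from compound 3 by 5-bromothiophen-2-yl in place of pyridin-2-yl on a carbonyl carbon. Among the compounds with values here, two measured steps bear on this. The step of a 6.7-fold higher number from compound 2 to compound 3 (0.82 log units; beyond the scatter) shows that pyridin-2-yl in place of thiophen-2-yl on the carbonyl carbon raised the number; read in reverse, returning to a thiophen-2-yl should lower it by a similar amount. The step of a 9.6-fold lower number from compound 1 to compound 2 (0.98 log units; beyond the scatter) likewise shows thiophen-2-yl at that carbonyl carbon giving the lowest number seen. Within the data shown here, no measured step covers the bromine on the thiophene, so that part of the change is unanchored. A modest decrease in this assay is therefore expected, about a 6.8-fold lower number from compound 3 to compound 4 (0.83 log units; beyond the scatter). For compound 4 the estimate is 900 nM, with a range from 300 nM to 3000 nM.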

Compound 4, half-maximal inhibitory concentration: 6250 nM
Compound 4: the middle estimate sits 6.9-fold (0.84 log units) below what was measured; measured number above the stated range.
By their numbers in this assay, from the lowest: compound 2; then compounds 3, 4 and 1 (each within the scatter of the next).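

In this assay, bromo in place of hydrogen on an aromatic carbon is a step of its own (a 6.8-fold higher number from compound 2 to compound 4 (0.83 log units; beyond the scatter)), so thiophen-2-yl on the carbonyl carbon does not by itself secure the low number of compound 2. Going by these compounds alone, with the bromine present, the group on this carbonyl carbon no longer separates the compounds (a 1.0-fold higher number from compound 3 to compound 4 (0.01 log units; within the scatter); a 1.4-fold lower number from compound 1 to compound 4 (0.15 log units; within the scatter)): 5-bromothiophen-2-yl, pyridin-2-yl and 3,4-dimethoxyphenyl all stand level, and only compound 2 lies apart from the rest. Nothing available accounts for this loss of the thiophene advantage.

Open, going by these compounds, is whether the change is specific to bromine or would also follow from a chloro or a methyl group in its place. Also open, on these data alone, is whether a furan-2-yl on the carbonyl carbon would fall with compound 2 or with the other three.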